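The source may hold more compounds than are shown below. What is called first, only, known or untested is meant among the compounds shown, and "the series" means these compounds.

Compound 1, `Brc1ccc(C2=NN(C3=NC(c4ccccc4)CS3)C(c3ccc4ccccc4c3)C2)cc1`, gives 20300 nM in a functional assay on HepG2 cells (Homo sapiens) for inhibition, read by CCK-8 assay, with a stated time of 48 h; on this read-out higher numbers stand for weaker inhibition and lower numbers for stronger inhibition.
Compound 2, `O=C1CSC(N2N=C(c3ccc(Br)cc3)CC2c2cccc3ccccc23)=N1`, gives 13400 nM in this assay.
Compound 3, `Brc1ccc(C2=NN(C3=NC(c4ccccc4)CS3)C(c3cccc4ccccc34)C2)cc1`, gives 15600 nM in this assay.

Among these three numbers compound 3 holds the second highest, yet all three sit within the scatter of one another: the step of a 1.3-fold lower number from compound 1 to compound 3 (0.11 log units; within the scatter) and the step of a 1.2-fold higher number from compound 2 to compound 3 (0.07 log units; within the scatter) are both too small to count as a real change. Compound 4, `c1ccc(C2=NN(C3=NC(c4ccccc4)CS3)C(c3cccc4ccccc34)C2)cc1`, differs from compound 3 in a single place: hydrogen in place of bromo on an aromatic carbon. Neither measured step touches this part of the molecule; one exchanges naphthalen-2-yl for naphthalen-1-yl on a saturated ring carbon, the other swaps the group on the amine nitrogen in a ring, and both stayed within the scatter. There is thus no measured guide for taking away the bromo, and the plain expectation is a 1.2-fold higher number from compound 3 to compound 4 (0.06 log units; within the scatter), a step that stays within the scatter. Compound 4 is accordingly estimated at 18000 nM, with a range from 7000 nM to 45000 nM.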

Compound 4, half-maximal inhibitory concentration: 13200 nM
Beside the measured number, compound 4's estimate is 1.4-fold (0.13 log units) above it, and the stated range covers the measured number.
By their numbers in this assay, from the lowest: compounds 4, 2, 3 and 1 (each within the scatter of the next).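

Exchanging bromo for hydrogen, which turns the 4-bromophenyl group into phenyl, is the first change shown at this aromatic carbon, and in this assay it gives a step within the scatter (a 1.2-fold lower number from compound 3 to compound 4 (0.07 log units; within the scatter)). In this one pair, then, the bromo is not required for a number of this size: compound 4, with only hydrogen at this place, stays level with compound 3. No measurement shown here accounts for this result.

On these data alone, whether a different group at this place, such as an amine, a methoxy group or a carboxylic acid, would move the number beyond the scatter remains open. So does whether taking away the bromo would give the same result in compound 1, which carries naphthalen-2-yl rather than naphthalen-1-yl.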